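The source may hold more compounds than are shown below. What is called first, only, known or untested is meant among the compounds shown, and "the series" means these compounds.

Compound 1 `Cc1ccc(-c2nc(CNc3ccc(C(=O)NO)cc3)n(-c3ccccc3)n2)o1`: 60.7%
Compound 2 `Cc1ccccc1-c1nc(CNc2ccc(C(=O)NO)cc2)n(-c2ccccc2)n1`: 53.2%
Compound 3 `Cc1cccc(-n2nc(-c3ccccc3)nc2CNc2ccc(C(=O)NO)cc2)c1`: 66%

In an assay on Sf9 cells for inhibition of protein deacetylase HDAC6 (Homo sapiens), read by fluorescence, with a stated time of 40 min, tested at 100 nM (a lower number here means less inhibition, a higher number more inhibition at the concentration tested (going by the name of the read-out)), compound 3 gives the highest of the three numbers, although the gap to compound 1 lies within the usual scatter, while the gap to compound 2 lies beyond it. Compound 4 `COc1ccc(-n2nc(-c3ccccc3)nc2CNc2ccc(C(=O)NO)cc2)cc1` differs from compound 3 in one place: 4-methoxyphenyl in place of 3-methylphenyl on an aromatic nitrogen. Among the compounds with values here, the only measured step, a number 7.5 percentage points lower from compound 1 to compound 2 (within the scatter), exchanges one aromatic group for another on an aromatic carbon and stays within the scatter, so no step bears directly on a change on the aromatic nitrogen. Compound 4 is therefore expected to remain near compound 3, with the step of a number 6 percentage points lower from compound 3 to compound 4 (within the scatter) expected to be small. The estimate for compound 4 is 60%, between 45% and 75%.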

Compound 4, a percentage reported as inhibition, at one concentration (the size of the read-out at that concentration, not a potency): 63.4%
Compound 4: the middle estimate sits 3.4 percentage points below what was measured, and the stated range covers the measured number.
By their numbers in this assay, from the lowest: compounds 2, 1, 4 and 3 (each within the scatter of the next, the first and the last beyond it).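

In this assay, within the data shown here, the step of a number 2.6 percentage points lower from compound 3 to compound 4 (within the scatter) gives the first view of a change on the aromatic nitrogen. Replacing 3-methylphenyl with 4-methoxyphenyl, which adds a hydrogen-bond acceptor, leaves the read-out within the usual scatter at this position. No measured evidence accounts for this result.

This single step changes both the kind of group and its place on the phenyl ring, so the two changes cannot be separated. Going by these compounds, how the position responds to an amine or a carboxylic acid on that ring, or to a longer alkyl chain replacing it, remains open.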